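A Piperidinylmethyl Group Tried on Two Fluorobenzophenone Cores

The source may report more compounds than this note shows. Statements on the series, on what has been measured and on what is new or still open speak of the compounds shown alone.

Compound 1, `COc1cc(O)c(C(=O)c2cccc(F)c2)c(OC)c1`, gives 38% in a functional assay on THP-1 cells (Homo sapiens) for inhibition, read by ELISA, with stated times of 30 min and 24 h, tested at 1 uM; a lower number here means a weaker effect, a higher number a stronger effect of the compound at the concentration tested. Compound 2, `COc1cc(OC)c(C(=O)c2cccc(F)c2)c(O)c1CN1CCCCC1`, carries (piperidin-1-yl)methyl in place of hydrogen on an aromatic carbon; compound 2 gives 30%, and the step is a number 8 percentage points lower from compound 1 to compound 2 (within the scatter). Compound 3, `COc1cc(O)c(C(=O)c2ccccc2F)c(OC)c1`, has the same atoms as compound 1 joined differently; the difference between the two cores is not broken down here. Compound 3 gives 11%, the lowest of the three numbers. Compound 4, `COc1cc(OC)c(C(=O)c2ccccc2F)c(O)c1CN1CCCCC1`, differs from compound 3 by (piperidin-1-yl)methyl in place of hydrogen on an aromatic carbon. This is the same kind of change as that from compound 1 to compound 2, but the place is meta to a (2-fluorophenyl)carbonyl group rather than meta to a (3-fluorophenyl)carbonyl group. Because a number 8 percentage points lower from compound 1 to compound 2 (within the scatter) stayed within the scatter, a similarly small step is expected, namely a number 3 percentage points lower from compound 3 to compound 4 (within the scatter). Compound 4 is therefore expected to give about 8%, with 0% and 25% as the expected ends.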

Compound 4, a percentage reported as activity, at one concentration (the size of the read-out at that concentration, not a potency): 18%
The estimate for compound 4 lay 10 percentage points below the measured number; measured number inside the range.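

In this assay, adding the (piperidin-1-yl)methyl group to the core with 2-fluorophenyl gives a number 7 percentage points higher from compound 3 to compound 4 (within the scatter), and with that group present, 2-fluorophenyl in place of 3-fluorophenyl gives a number 12 percentage points lower from compound 2 to compound 4 (beyond the scatter). Each addition is small on its own, yet the two do not match, so the change does not carry from one core to the other as one fixed step: the same change on two cores in this assay, a number 8 percentage points lower (within the scatter) from compound 1 to compound 2 and a number 7 percentage points higher (within the scatter) from compound 3 to compound 4, 15 percentage points apart, beyond the scatter of two such steps This rests on a single pair per core at one concentration, and it does not show why the cores differ.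

Still open, from the compounds shown here alone, is whether another group in the same place, such as (morpholin-4-yl)methyl or a carboxylic acid, would differ between the cores in the same way. Going by these compounds, how a 4-fluorophenyl core would respond is also open.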